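The source may hold more compounds than are shown below. What is called first, only, known or untested is meant among the compounds shown, and "the series" means these compounds.

Compound 1 `CN1CCN(c2cc(C(F)(F)F)ccc2[C@H]2CCOc3cc(S(=O)(=O)Nc4nccs4)ccc32)CC1`: 2.1
Compound 2 `Cn1nccc1-c1cc(C(F)(F)F)ccc1[C@H]1CCOc2cc(S(=O)(=O)Nc3nccs3)ccc21`: 2.2
Compound 3 `Cc1nc(-c2cc(C(F)(F)F)ccc2[C@H]2CCOc3cc(S(=O)(=O)Nc4nccs4)ccc32)co1`: 2.9

In a physicochemical assay for lipophilicity (a lower number here means a more polar compound, a higher number a more lipophilic compound), compound 3 stands highest of the three at 2.9, with both others beyond the scatter from it. Compound 4 `O=S(=O)(Nc1nccs1)c1ccc2c(c1)OCC[C@@H]2c1ccc(C(F)(F)F)cc1N1CCNCC1` has not been measured yet. It carries piperazin-1-yl in place of 2-methyl-1,3-oxazol-4-yl on an aromatic carbon.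

The closest evidence is the exchange of 4-methylpiperazin-1-yl for 2-methyl-1,3-oxazol-4-yl at the same place, which gave a number 0.80 log units higher from compound 1 to compound 3 (beyond the scatter). The exchange of 1-methyl-1H-pyrazol-5-yl for that same oxazole gave a similar a number 0.70 log units higher from compound 2 to compound 3 (beyond the scatter), while a number 0.10 log units higher from compound 1 to compound 2 (within the scatter) shows that the other two groups do not separate. Within the data shown here, no measured pair shows what piperazin-1-yl does compared with 4-methylpiperazin-1-yl, so this comparison is only approximate.

Reading a number 0.80 log units higher from compound 1 to compound 3 (beyond the scatter) backwards, a fall of similar or slightly larger size seems likely. The expected change is a number 1.00 log units lower from compound 3 to compound 4 (beyond the scatter), which would lie beyond the scatter. The estimate for compound 4 is 1.9, with an expected range from 1.4 to 2.4.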

Compound 4, distribution coefficient: 1.4
For compound 4 the middle estimate is 0.50 log units above the measured one; measured number inside the range.
By their numbers in this assay, from the lowest: compound 4; then compounds 1 and 2 (each within the scatter of the next); then compound 3.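

In this assay hydrogen in place of methyl on the amine nitrogen in the ring gives a number 0.70 log units lower from compound 1 to compound 4 (beyond the scatter) and so shows that the number at this position can move with one small edit inside a group, not only when one ring is exchanged for another. Piperazin-1-yl also stands apart from both aromatic groups, with a number 0.80 log units lower from compound 2 to compound 4 (beyond the scatter) and with a number 1.50 log units lower from compound 3 to compound 4 (beyond the scatter) as the widest step seen at this position. No measurement comes with these numbers that could explain them, so only the sizes of the steps are known.

As far as these compounds go, it remains open whether a morpholine ring or an open-chain amine on this aromatic carbon would give a number closer to that of compound 1 or compound 4. The compounds shown also leave open whether an ethyl group on the ring nitrogen would continue the step seen with methyl.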